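Aryl Swaps at the Acetal Carbon of a Shared Core

This account rests on a few compounds, and the source may have more. Where it says the series, first, only, none or still open, it means among the compounds named here.

Measured so far in an assay for inhibition of Thromboxane-A synthase (Homo sapiens), using microsomes; on this read-out lower numbers stand for stronger inhibition and higher numbers for weaker inhibition:
- Compound 1, `O=C(O)CC/C=C\CC1COC(c2ccccc2Cl)OC1c1cccnc1`: 48 nM
- Compound 2, `N#Cc1ccc(C2OCC(C/C=C\CCC(=O)O)C(c3cccnc3)O2)cc1`: 24 nM
- Compound 3, `O=C(O)CC/C=C\CC1COC(c2ccc([N+](=O)[O-])cc2)OC1c1cccnc1`: 39 nM

All three compounds share one core and differ only in the aromatic group that sits on the saturated ring carbon between two ring oxygen atoms. Compound 3 holds the second highest of the three numbers in this assay; its nearest neighbour is compound 1, and the gap is a 1.2-fold lower number from compound 1 to compound 3 (0.09 log units; within the scatter) in the other direction, while compound 2 lies furthest, at a 1.6-fold higher number from compound 2 to compound 3 (0.21 log units; within the scatter). Both gaps sit within the scatter, so none of the three can be called stronger or weaker than another.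

Compound 4, `O=C(O)CC/C=C\CC1COC(c2ccsc2)OC1c1cccnc1`, is the next variation at the same position: thiophen-3-yl in place of 4-nitrophenyl on a saturated ring carbon.

For the measured compounds named here, the steps that bear on this change are the earlier swaps at this carbon, a 2.0-fold lower number from compound 1 to compound 2 (0.30 log units; within the scatter) and a 1.2-fold lower number from compound 1 to compound 3 (0.09 log units; within the scatter), together with a 1.6-fold higher number from compound 2 to compound 3 (0.21 log units; within the scatter). Every one of them stayed within the scatter, so no step beyond the scatter is expected in this assay for the move to a thiophen-3-yl group either; the expected step is a 1.0-fold higher number from compound 3 to compound 4 (0.01 log units; within the scatter). Compound 4 is therefore estimated at 40 nM, with a range from 15 nM to 120 nM.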

Compound 4, half-maximal inhibitory concentration: 500 nM
Estimate against measurement, compound 4: 13-fold (1.10 log units) below, and the stated range ends below it.
By their numbers in this assay, from the lowest: compounds 2, 3 and 1 (each within the scatter of the next); then compound 4.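

In this assay, the 2-chlorophenyl, 4-cyanophenyl and 4-nitrophenyl groups all stayed within the scatter of one another, which made this saturated ring carbon look tolerant of aromatic swaps. Thiophen-3-yl shows that this tolerance has a limit, since all three steps to it lie beyond the scatter (a 13-fold higher number from compound 3 to compound 4 (1.11 log units; beyond the scatter); a 21-fold higher number from compound 2 to compound 4 (1.32 log units; beyond the scatter); a 10-fold higher number from compound 1 to compound 4 (1.02 log units; beyond the scatter)), leaving the three compounds with a six-membered aromatic ring of carbon only on one side and compound 4, with its five-membered aromatic ring, alone on the weaker side. No measurement shown here accounts for this loss of inhibition.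

The change to compound 4 alters several things at once, namely ring size, the sulfur hetero atom and the absence of any group on the ring, and these four compounds cannot separate them. A plain phenyl group would test whether the substituents on the six-membered rings matter, while a furan-3-yl group would test whether the five-membered ring behaves the same way with oxygen in place of sulfur.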